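The source may hold more compounds than are shown below. What is called first, only, known or untested is meant among the compounds shown, and "the series" means these compounds.

In a functional assay on NALM-6 cells (Homo sapiens) for cytotoxicity, with a stated time of 72 h (on this read-out lower numbers stand for an effect already at smaller amounts and higher numbers for an effect only at larger amounts of compound), compound 1 (`C=C[C@@](C)(/C=C/c1ccc(OS(=O)(=O)C(F)(F)F)cc1)CCC=C(C)C`) gives > 43400 nM as a limit of the assay, not a number. Compound 2 (`C=C[C@@](C)(/C=C/c1ccc(O)cc1)CCC=O`) also gives > 43400 nM as a limit, so it stands without a measured number. Compound 3 (`C=C[C@@](C)(/C=C/c1ccc(O)cc1)CC/C=C/C(=O)OCC`) carries 2-(ethoxycarbonyl)ethenyl in place of the formyl of compound 2, on a saturated chain carbon, three bonds along the chain from two double-bonded chain carbons (2-(ethoxycarbonyl)ethenyl in place of formyl on a saturated chain carbon, three bonds along the chain from two double-bonded chain carbons). Within the data shown here, no measured step guides this change, so only a modest move towards lower numbers is expected in this assay and the result may remain a limit. The estimate means an at least 1.7-fold lower number from compound 2 to compound 3 (0.23 log units; that floor lies within the scatter) as an expected step. Compound 3 is estimated at 25000 nM with an expected range from 8000 nM to 60000 nM in this estimate.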

Compound 3, half-maximal effective concentration: > 43400 nM
Compound 3 gave a limit, no number; the forecaster's own chance of this, stated with the estimate: 50%; middle value at least 1.7-fold (0.23 log units) away from the limit.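

Compound 2 and compound 3 both stand only as limits, not numbers, in this assay, so no step between them can be read: the limit of > 43400 nM in this assay, at which 3 of the 3 values shown sit.

The compounds shown leave open which change, if any, would give a measured number in this assay.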